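Fluorinated Acyl Groups on a Shared Piperidine Carbamate Core

The compounds below may be only part of what the source reports. "The series", "measured", "known", "first", "only" and "open" are said of these compounds alone.

Measured compounds:
Compound 1, `Cc1nc(S(C)(=O)=O)ccc1Oc1ncnc(OC2CCN(C(=O)O[C@@H](C)C(F)(F)F)CC2)c1F`: 109 nM
Compound 2, `Cc1nc(S(C)(=O)=O)ccc1Oc1ncnc(OC2CCN(C(=O)SC(C)(C)C)CC2)c1F`: 30.7 nM
Compound 3, `Cc1nc(S(C)(=O)=O)ccc1Oc1ncnc(OC2CCN(C(=O)C(C)(F)F)CC2)c1F`: 239 nM

All three compounds share the same core and differ only in the group attached to the carbonyl carbon on the ring nitrogen. In a functional assay on isolated protein for inhibition of Glucose-dependent insulinotropic receptor (Rattus norvegicus), read by HTRF and cAMP accumulation (a higher number here means that more compound is needed for the effect, a lower number that less compound is needed), compound 3 gives 239 nM, the highest number of the three. Its nearest neighbour is compound 1, with a 2.2-fold higher number from compound 1 to compound 3 (0.34 log units; beyond the scatter); compound 2 is furthest, with a 7.8-fold higher number from compound 2 to compound 3 (0.89 log units; beyond the scatter).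

Compound 4, `Cc1nc(S(C)(=O)=O)ccc1Oc1ncnc(OC2CCN(C(=O)C3(F)CCC3)CC2)c1F`, has not yet been measured. It differs from compound 3 by a group of 5 heavy atoms (4 carbon, 1 fluorine; one four-membered non-aromatic ring of carbon only) in place of a group of 4 heavy atoms (2 carbon, 2 fluorine; no ring), on a carbonyl carbon. The measured steps that bear on this are those at the same carbonyl carbon, from compound 1 to compound 3 and from compound 2 to compound 3, both modest and both pointing to compound 3 as the weakest of the set. Only these two steps are available, and neither involves a ring, so the direction for compound 4 is uncertain; a small shift toward the other compounds seems the more likely outcome, and compound 4 is therefore expected at 150 nM, within 50 nM to 500 nM, a step of a 1.6-fold lower number from compound 3 to compound 4 (0.20 log units; within the scatter).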

Compound 4, half-maximal effective concentration: 123 nM
Beside the measured number, compound 4's estimate is 1.2-fold (0.09 log units) above it; measured number inside the range.
By their numbers in this assay, from the lowest: compound 2; then compounds 1, 4 and 3 (each within the scatter of the next, the first and the last beyond it).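

In this assay a four-membered ring of carbon only is accepted on the carbonyl carbon, and it cannot be told apart from the open 1,1-difluoroethyl group, with a 1.9-fold lower number from compound 3 to compound 4 (0.29 log units; within the scatter) for that exchange. Nor can it be told apart from the 1-(trifluoromethyl)ethoxy group, with a 1.1-fold higher number from compound 1 to compound 4 (0.05 log units; within the scatter) for that exchange. The (tert-butyl)sulfanyl group remains clearly separate from the ring, although both groups count 5 heavy atoms, with a 4.0-fold higher number from compound 2 to compound 4 (0.60 log units; beyond the scatter) on this exchange. No measurement here offers a reason for any of these steps.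
The compounds shown leave open what the single fluorine on the ring contributes, as a plain cyclobutyl group does not appear among them. They also leave open how a cyclopropyl or cyclopentyl ring, or a tert-butyl group bonded directly to the carbonyl carbon, would read in this assay at this position.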